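The source may report more compounds than this note shows. Statements on the series, on what has been measured and on what is new or still open speak of the compounds shown alone.

In a functional assay on KBVIN cells (Homo sapiens) for antiproliferative activity, read by sulforhodamine B assay, with a stated time of 3 days (a higher number here means that more compound is needed for the effect, a lower number that less compound is needed), compound 2 `CCC1=C(O)c2c(oc(-c3ccc(Br)cc3)cc2=O)C(CC)(CC)C1=O` gives 15.7 uM, the second highest of the three numbers on hand. Compound 1 `CCC1=C(O)c2c(oc(-c3ccc(CC(C)C)cc3)cc2=O)C(CC)(CC)C1=O` gives 17.4 uM, and the step of a 1.1-fold lower number from compound 1 to compound 2 (0.04 log units; within the scatter) lies within the scatter. Compound 3 `CCC1=C(O)c2c(oc(-c3ccc(OC)c(C)c3C)cc2=O)C(CC)(CC)C1=O` gives 0.28 uM, far lower than compound 2 and well beyond the scatter. Compound 4 `CCC1=C(O)c2c(oc(-c3ccc(O)c(O)c3)cc2=O)C(CC)(CC)C1=O` has not been measured; it differs from compound 2 by 3,4-dihydroxyphenyl in place of 4-bromophenyl on an aromatic carbon. Within the data shown here, the only step on record, a 1.1-fold lower number from compound 1 to compound 2 (0.04 log units; within the scatter), concerns a different exchange and so offers little guidance, while the gap between compound 2 and compound 3 shows that an oxygen-bearing aryl group can go with a much lower number. Compound 4 is therefore expected to give 3 uM, with a range of 0.5 uM to 18 uM. This estimate means a step of a 5.2-fold lower number from compound 2 to compound 4 (0.72 log units; beyond the scatter).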

Compound 4, concentration for half-maximal effect: 5.41 uM
The estimate for compound 4 lay 1.8-fold (0.26 log units) below the measured number; the range from low to high includes it.
By their numbers in this assay, from the lowest: compound 3; then compound 4; then compounds 2 and 1 (each within the scatter of the next).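

In this assay putting 3,4-dihydroxyphenyl in place of 4-bromophenyl gives a 2.9-fold lower number from compound 2 to compound 4 (0.46 log units; beyond the scatter) and so moves the number beyond the scatter, which the earlier step of bromo in place of isobutyl did not do. The change is modest: compound 4 gives 5.41 uM while compound 3 gives 0.28 uM and so stays lower, which shows that oxygen-bearing aryl groups at this position do not all give the same number. As far as these compounds go, whether an amine or a methoxy group in place of the two hydroxyl groups would give a lower number stays open. Nothing on hand explains the step.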